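Moving the ring nitrogen in a triazine-type agonist series

The source may report more compounds than this note shows. Statements on the series, on what has been measured and on what is new or still open speak of the compounds shown alone.

Three measured compounds share one core and differ only in the group reached through the oxygen. Compound 1 `CCCCNc1nc(N)nnc1OCc1ccccc1F` carries 2-fluorophenyl on the saturated chain carbon bound to the oxygen on the aromatic ring; in an assay on isolated protein for agonist activity at Toll-like receptor 8 (Homo sapiens) (a higher number here means that more compound is needed for the effect, a lower number that less compound is needed), compound 1 gives 560 nM. Compound 2 `CCCCNc1nc(N)nnc1OCc1ccccn1` has pyridin-2-yl in that place, and in this assay compound 2 gives 330 nM, the lowest of the three numbers, although the step of a 1.7-fold lower number from compound 1 to compound 2 (0.23 log units; within the scatter) stays within the scatter. Compound 3 `CCCCNc1nc(N)nnc1OCCCc1ccccc1` reaches a phenyl through a longer saturated chain; in this assay compound 3 gives 1930 nM, a number beyond the scatter from compound 2.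

Compound 4 `CCCCNc1nc(N)nnc1OCc1cccnc1` has the same atoms as compound 2, joined differently: pyridin-3-yl in place of pyridin-2-yl on a saturated chain carbon bound to an oxygen on an aromatic ring. Going by the values given here, no measured step shifts the nitrogen within the ring. Among the compounds with values here, the only measured change at this position, from 2-fluorophenyl to pyridin-2-yl, stayed within the scatter, and the one large loss came from lengthening the chain, which compound 4 does not do. The expected step is therefore a 1.4-fold higher number from compound 2 to compound 4 (0.13 log units; within the scatter), not beyond the scatter, leaning if anything to a slightly higher number. For compound 4 the estimated value is 450 nM, in a range from 200 nM to 1200 nM.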

Compound 4, half-maximal effective concentration: 590 nM
Compound 4: the middle estimate sits 1.3-fold (0.12 log units) below what was measured, within the range that was stated.
By their numbers in this assay, from the lowest: compounds 2, 1 and 4 (each within the scatter of the next); then compound 3.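

Moving the ring nitrogen is now a measured change at this position, which the earlier compounds did not offer: in this assay, pyridin-3-yl in place of pyridin-2-yl on the saturated chain carbon bound to the oxygen gives a 1.8-fold higher number from compound 2 to compound 4 (0.25 log units; within the scatter) and so does not separate the two pyridine groups. The comparison with the fluorinated ring gives a 1.1-fold higher number from compound 1 to compound 4 (0.02 log units; within the scatter) and adds a second step within the scatter, so 2-fluorophenyl, pyridin-2-yl and pyridin-3-yl at this place, in compounds 1, 2 and 4, cannot be told apart in this assay, and neither the presence of a ring nitrogen nor the place it holds in the ring is shown to change the number. No supporting data bear on this result or offer any account of it.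

Going by these compounds, whether this tolerance holds for a ring carrying an amine or a carboxylic acid on the saturated chain carbon bound to the oxygen remains open. Also open, on these data alone, is whether a longer chain ending in pyridin-2-yl or pyridin-3-yl would behave as the phenyl of compound 3 does.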